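The source may hold more compounds than are shown below. What is called first, only, known or untested is meant among the compounds shown, and "the series" means these compounds.

Compound 1 `C#CCOc1ccc2oc(=O)ccc2c1` in a functional assay on A549 cells (Homo sapiens) for cytotoxicity, read by MTT assay, with a stated time of 48 h; a higher number here means a weaker inhibitor, a lower number a stronger inhibitor: 24000 nM. Compound 2 `O=c1ccc2cc(OCc3cc(-c4ccccc4)no3)ccc2o1`: "not determined" (no result reported).

Going by these compounds, compound 2 stands without a number in this assay, so its own level is unknown; only compound 1, which shares the core with it, gives a value there, 24000 nM, a weak result. Compound 3 `O=c1ccc2cc(OCc3cc(-c4cccc([N+](=O)[O-])c4)no3)ccc2o1` differs from compound 2 by nitro in place of hydrogen on an aromatic carbon, meta to a large group. Within the data shown here, no measured pair shows the effect of this change, so no step size can be read off; no shift beyond the usual scatter is expected. Compound 3 is therefore expected at 15000 nM, within 3000 nM to 80000 nM.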

Compound 3, half-maximal inhibitory concentration: 36200 nM
The estimate for compound 3 lay 2.4-fold (0.38 log units) below the measured number, within the range that was stated.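

No new step can be read between compound 2 and compound 3 in this assay: only compound 3 carries a number there. Going by these compounds, what the change from phenyl to 3-nitrophenyl does to the result stays open. Nothing shown offers an explanation for the value of compound 3.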